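Chloro for fluoro: from compound 2 to compound 3

This account rests on a few compounds, and the source may have more. Where it says the series, first, only, none or still open, it means among the compounds named here.

In a functional assay on NCI/ADR-RES cells (Homo sapiens) for cytotoxicity (a higher number here means a weaker inhibitor of growth, a lower number a stronger inhibitor of growth), compound 1 `COc1ccc(NS(=O)(=O)c2c(F)c(F)c(F)c(F)c2Br)cc1` gives 160 nM and compound 2 `COc1ccc(NS(=O)(=O)c2cc(F)c(F)c(F)c2F)cc1` gives 400 nM, the higher of the two numbers.

Compound 3 `COc1ccc(NS(=O)(=O)c2cc(F)c(Cl)c(F)c2F)cc1` has not yet been measured. It differs from compound 2 in one place: chloro in place of fluoro on an aromatic carbon. This is chloro in place of fluoro on an aromatic carbon, ortho to two fluoro groups, meta to a fluoro group and para to a large group.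

Going by the values given here, only one measured step bears on this change: a 2.5-fold higher number from compound 1 to compound 2 (0.40 log units; beyond the scatter), a modest step beyond the scatter, with hydrogen in place of bromo on an aromatic carbon. It involves a different halogen on a different carbon and replaces it with hydrogen, so it is only a loose guide. Read in reverse, it links a halogen gain to a lower number, so a modest move to a lower number is expected, though a result within the scatter would not surprise.

The expected change is a 1.6-fold lower number from compound 2 to compound 3 (0.20 log units; within the scatter).

Compound 3 is estimated at 250 nM, with an expected range of 100 nM to 600 nM.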

Compound 3, concentration for 50% growth inhibition: 22000 nM
The estimate for compound 3 lay 88-fold (1.94 log units) below the measured number; the whole stated range lies below it.
By their numbers in this assay, from the lowest: compound 1; then compound 2; then compound 3.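

In this assay, this carbon, para to a large group and ortho to two fluoro groups, is highly sensitive to the identity of its halogen: chloro in place of fluoro gives a 55-fold higher number from compound 2 to compound 3 (1.74 log units; beyond the scatter). Going by these compounds alone, that exchange moves the number much further than the only other step, a 2.5-fold higher number from compound 1 to compound 2 (0.40 log units; beyond the scatter), which involves hydrogen in place of bromo on a different carbon. Gaining a heavier halogen therefore does not carry a general link to a lower number across these compounds, and compound 3 goes directly against the trend suggested by the earlier pair. No measurement at hand accounts for the size of this step.

Going by these compounds, it remains open whether the sharp rise is particular to chloro, or whether hydrogen, a methoxy group or an amine on the same carbon would keep the number close to that of compound 2 at 400 nM. Also open, on these data alone, is whether chloro in place of fluoro on the other fluoro-bearing carbons of the ring would produce a step of similar size.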